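Halogen position and swap on the anilino aryl

A few compounds are considered here, and "the series" means these few. Any claim that something is new, unique, unknown or untested is made for them only; others in the source may bear on it.

Compound 1 `COc1ccc(-n2nnnc2Nc2ccccc2Cl)cc1` is the reference point of this set. In an ADME assay on HaCaT cells (Homo sapiens) for cytotoxicity, read by MTT assay, with a stated time of 72 h (a higher number here means a weaker inhibitor, a lower number a stronger inhibitor), compound 1 gives 134000 nM, the highest of the three numbers here, though both neighbours sit within the scatter of it. Compound 2 `COc1ccc(Nc2nnnn2-c2cccc(Cl)c2)cc1` gives 103000 nM and compound 3 `COc1ccc(Nc2nnnn2-c2ccccc2Cl)cc1` gives 100000 nM. Going by the values given here, the one single-point step measured so far, a 1.0-fold lower number from compound 2 to compound 3 (0.01 log units; within the scatter), moves the chlorine between two positions of the phenyl on the aromatic nitrogen and changes nothing beyond the scatter.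

Compound 4 `COc1ccc(-n2nnnc2Nc2cccc(Br)c2)cc1` has not been measured. Relative to compound 1 it differs in one place: 3-bromophenyl in place of 2-chlorophenyl on a nitrogen on an aromatic ring. This change combines a shift of the halogen position with a chlorine-to-bromine swap, on the nitrogen rather than the ring nitrogen of the core. Among the compounds with values here, the only related step, from compound 2 to compound 3, was flat, and no chlorine-to-bromine comparison exists in the set. The expectation is therefore no step beyond the scatter, a 1.2-fold lower number from compound 1 to compound 4 (0.07 log units; within the scatter). Compound 4 is estimated at 115000 nM, with a range from 65000 nM to 200000 nM.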

Compound 4, half-maximal inhibitory concentration: 138000 nM
The estimate for compound 4 lay 1.2-fold (0.08 log units) below the measured number; measured number inside the range.
By their numbers in this assay, from the lowest: compounds 3, 2, 1 and 4 (each within the scatter of the next).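

In this assay, the 3-bromophenyl in place of 2-chlorophenyl on a nitrogen on an aromatic ring gives a 1.0-fold higher number from compound 1 to compound 4 (0.01 log units; within the scatter), so a bromine and a different halogen position on this aryl produce no separation from compound 1. Compound 2 and compound 3 covered only chlorine on the phenyl on an aromatic nitrogen, whereas this step extends the flat picture to the other aryl and to a heavier halogen, with all four compounds forming a run in which each lies within the scatter of the next. No available data bear on why these numbers do not separate.

With both changes combined in one step, the contributions of halogen position and halogen identity cannot be told apart. From the compounds shown here alone, it remains open whether an amine or a carboxylic acid on this phenyl would give a number beyond the scatter of compound 1.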